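Swapping methoxy for chloro on a rigid arylsulfonamide scaffold

The compounds below may be only part of what the source reports. "The series", "measured", "known", "first", "only" and "open" are said of these compounds alone.

Of the compounds shown here, three have been tested in an assay on isolated protein for binding affinity to Alpha-1D adrenergic receptor (Rattus norvegicus), read by radioligand binding; a lower number here means a stronger inhibitor, a higher number a weaker inhibitor. Compound 1 `COc1ccc2c(c1NS(C)(=O)=O)CCCC2c1c[nH]cn1` gives 479 nM in this assay. Compound 2 `CCS(=O)(=O)Nc1cc(C2CCCCC2)cc2c1CCCC2c1c[nH]cn1` gives 447 nM in this assay, a value within the usual scatter of that for compound 1. For compound 3 `COc1ccc(NS(C)(=O)=O)c2c1C(c1c[nH]cn1)CCC2` this assay reports only a limit, < 10000 nM, so its true value is known only as a bound (the limit of < 10000 nM in this assay, at which 1 of the 3 values shown sits). Compound 4 `CS(=O)(=O)Nc1ccc(Cl)c2c1CCCC2c1c[nH]cn1` is not yet measured; it differs from compound 3 by chloro in place of methoxy on an aromatic carbon. Going by the values given here, with no measured step to guide the size of this change, the expected step from compound 3 to compound 4 is a step that the limit leaves unreadable from compound 3 to compound 4. Compound 4 is therefore estimated at 2000 nM, within a range from 300 nM to 10000 nM.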

Compound 4, inhibition constant: 2880 nM
For compound 4 the middle estimate is 1.4-fold (0.16 log units) below the measured one; the measured number falls inside the stated range.
By their numbers in this assay, from the lowest: compounds 2 and 1 (each within the scatter of the next); then compound 4.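

No step can be read from compound 3 to compound 4, because compound 3 carries only a limit: the limit of < 10000 nM in this assay, at which 1 of the 4 values shown sits.

Going by these compounds, how much chloro in place of methoxy on an aromatic carbon shifts the binding affinity remains open.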